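Compound 3: cyano in place of cyclohexyl

The source may report more compounds than this note shows. Statements on the series, on what has been measured and on what is new or still open speak of the compounds shown alone.

In a functional assay (Homo sapiens) for inhibition (a lower number here means a stronger inhibitor, a higher number a weaker inhibitor), compound 2 `Fc1ccc(-c2[nH]c(SCC3CCCCC3)nc2-c2ccncc2)cc1` gives 240 nM and compound 1 `Fc1ccc(-c2[nH]c(SCc3ccccc3)nc2-c2ccncc2)cc1` gives 300 nM, so the two stand level within the scatter. Compound 3 `N#CCSc1nc(-c2ccncc2)c(-c2ccc(F)cc2)[nH]1` carries cyano in place of cyclohexyl on a saturated chain carbon bound to a sulfur. For the measured compounds named here, the only measured step bearing on this is a 1.3-fold lower number from compound 1 to compound 2 (0.10 log units; within the scatter), cyclohexyl in place of phenyl, and it lies within the scatter. Going by the values given here, no measured compound lacks a ring at that place, so the data do not test this change. A modest move toward a weaker inhibitor in this assay is expected, an estimated 2.1-fold higher number from compound 2 to compound 3 (0.32 log units; beyond the scatter). Compound 3 is estimated at 500 nM, with an expected range of 150 nM to 1800 nM.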

Compound 3, half-maximal inhibitory concentration: < 100 nM
Compound 3 gave a limit, no number; the forecaster's own chance of this, stated with the estimate: 10%; at least 5.0-fold (0.69 log units) between middle value and limit.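

In this assay the result for compound 3 is a limit, not a number: the limit of < 100 nM in this assay, at which 1 of the 3 values shown sits. Cyano gives an at least 2.4-fold lower number from compound 2 to compound 3 (0.38 log units; beyond the scatter), and in place of phenyl it gives an at least 3.0-fold lower number from compound 1 to compound 3 (0.47 log units; beyond the scatter). A ring on the saturated chain carbon bound to a sulfur is therefore not required, and this ringless group moves the number beyond the scatter, where the swap between phenyl and cyclohexyl did not.

As far as these compounds go, the full size of the step stays open. Also open, from the compounds shown here alone, is whether the nitrile or the loss of the ring drives it; a plain methyl, an amine or a carboxylic acid at this place would separate the two.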